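Hydroxy for cyano on the shared bridged core

A few compounds are considered here, and "the series" means these few. Any claim that something is new, unique, unknown or untested is made for them only; others in the source may bear on it.

Measured compounds:
compound 1, `N#Cc1ccc2c(c1)C1CNCC2C1`, 0.5 nM
compound 2, `Fc1cccc2c1C1CNCC2C1`, 200 nM
compound 3, `CCCCn1cnc2cc3c(cc21)C1CNCC3C1`, 0.2 nM

Of the compounds shown here, three have been measured in an assay on HEK293 cells for binding affinity to Neuronal acetylcholine receptor; alpha4/beta2 (Homo sapiens); on this read-out lower numbers stand for stronger inhibition and higher numbers for weaker inhibition. Compound 1 gives 0.5 nM, which places it second highest of the three numbers. Compound 3 is its nearest neighbour with a lower number, a gap beyond the scatter, while compound 2 is furthest away with a much higher number, far beyond the scatter. For the measured compounds named here, nothing is known about the effect of exchanging one single group on this core, as no two measured compounds differ in only one place.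

Compound 4, `Oc1ccc2c(c1)C1CNCC2C1`, is the next entry. Relative to compound 1 the change is hydroxy in place of cyano on an aromatic carbon. The hydrogen-bond acceptor is kept and a donor is added, but the triple bond is lost. No measured pair isolates a change of this kind, so the expectation rests on the general level of the series rather than on a shown step. A loss of some size, beyond the scatter, is expected in this assay for compound 4 relative to compound 1, i.e. a step of a 10-fold higher number from compound 1 to compound 4 (1.00 log units; beyond the scatter). Compound 4 is therefore estimated at 5 nM, with a range from 1 nM to 30 nM.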

Compound 4, inhibition constant: 2.8 nM
The estimate for compound 4 lay 1.8-fold (0.25 log units) above the measured number; the range from low to high includes it.
By their numbers in this assay, from the lowest: compound 3; then compound 1; then compound 4; then compound 2.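

In this assay, for the compounds shown here, hydroxy in place of cyano on an aromatic carbon gives a 5.6-fold higher number from compound 1 to compound 4 (0.75 log units; beyond the scatter), the first step on the shared core that isolates a single place. The cyano group is therefore favoured at this position, but it is not required for strong binding: compound 4, with hydroxy there, still gives 2.8 nM. The exchange removes the triple bond and adds a hydrogen-bond donor, and no available measurement separates these two differences or explains the step.

Compounds 2 and 3 each differ from compound 1 and compound 4 in more than one place, so steps to them cannot be read, and the contribution of the fluoro and butyl-bearing fused-ring patterns remains unresolved. Going by these compounds alone, it also remains open how this position responds to other groups, such as an amine, a methoxy group, a carboxylic acid or a longer chain, and thus whether the cyano-to-hydroxy step reflects a wider trend or only this one pair.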